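Methylating the Second Hydroxy Group of a Stilbene Diol

The source may hold more compounds than are shown below. What is called first, only, known or untested is meant among the compounds shown, and "the series" means these compounds.

Measured so far:
Compound 1 `Oc1ccc(/C=C/c2ccccc2O)cc1` gives 22 ug/mL in a functional assay on HT-29 cells (Homo sapiens) for inhibition, read by MTT assay, with a stated time of 2 days; on this read-out lower numbers stand for stronger inhibition and higher numbers for weaker inhibition.
Compound 2 `COc1ccc(/C=C/c2ccccc2O)cc1` gives 10 ug/mL in this assay.

Compound 1 stands at the higher of the two numbers recorded so far, meaning the weaker inhibition; its nearest neighbour is compound 2, reached by a single change that produced a 2.2-fold lower number from compound 1 to compound 2 (0.34 log units; beyond the scatter).

Compound 3 `COc1ccccc1/C=C/c1ccc(O)cc1` has not yet been measured. It differs from compound 1 by methyl in place of hydrogen on an oxygen on an aromatic ring; cut one bond further out, the change reads hydroxy to methoxy. This is the same kind of change that turned compound 1 into compound 2, applied now to the other of the two hydroxy groups that compound 1 carries.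

Within the data shown here, the only step that bears on this question is the one from compound 1 to compound 2, which gave a modest lowering of the number, just beyond the usual scatter. With a single precedent and a change at a different place on the molecule, the expectation is a step of similar modest size in the same direction in this assay, with the range wide enough to include no change at all. Compound 3 is therefore estimated at 12 ug/mL, between 6 ug/mL and 25 ug/mL, which would amount to a 1.8-fold lower number from compound 1 to compound 3 (0.26 log units; within the scatter).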

Compound 3, half-maximal inhibitory concentration: 24 ug/mL
Compound 3: the middle estimate sits 2.0-fold (0.30 log units) below what was measured, and the stated range covers the measured number.
By their numbers in this assay, from the lowest: compound 2; then compounds 1 and 3 (each within the scatter of the next).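

In this assay, the same swap of hydroxy to methoxy now has two outcomes within one molecule, and which outcome appears depends on which hydroxy group of compound 1 receives the methyl. At this second oxygen the result is a 1.1-fold higher number from compound 1 to compound 3 (0.04 log units; within the scatter) so the two numbers cannot be told apart, whereas the first oxygen gave a 2.2-fold lower number from compound 1 to compound 2 (0.34 log units; beyond the scatter) and that step lies beyond the usual scatter. The lower number of compound 2 therefore does not follow from this change wherever it is made on the shared core, and no measurement here accounts for the difference between the two hydroxy groups.

Still open, on these data alone, is whether a longer chain on this oxygen, such as ethyl or propyl, or an amine in place of the hydroxy group, would move the number at this position. Also open, as far as these compounds go, is what a methoxy group at both oxygens would give, and whether the contrast between the two oxygens holds beyond this one cell line.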